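Hydrazide series on MCF7 cells: exchange at the carbonyl

This account rests on a few compounds, and the source may have more. Where it says the series, first, only, none or still open, it means among the compounds named here.

Compound 1 `Cn1cnc(C(=O)NNC(=O)COc2ccc(C(=O)c3ccccc3)cc2)c1` and compound 2 `Cn1cnc(C(=O)NNC(=O)COc2c(F)cc(C(=O)c3ccc(Cl)cc3)cc2Cl)c1` together with compound 3 `O=C(COc1ccc(C(=O)c2ccccc2)cc1)NNC(=O)c1ccc(=O)oc1` are the measured members; compound 4 `O=C(COc1c(F)cc(C(=O)c2ccc(Cl)cc2)cc1Cl)NNC(=O)c1ccc(=O)oc1` remains to be tested. In a functional assay on MCF7 cells (Homo sapiens) for cytotoxicity, read by LDH release, with a stated time of 48 h (on this read-out lower numbers stand for stronger inhibition and higher numbers for weaker inhibition), compound 1 gives 31600 nM and compound 3 gives 61100 nM on the same read-out, while compound 2 gives 44400 nM there. Compound 1 turns into compound 3 by a group of 7 heavy atoms (5 carbon, 2 oxygen; one six-membered aromatic ring with 1 hetero atom) in place of a group of 6 heavy atoms (4 carbon, 2 nitrogen; one five-membered aromatic ring with 2 hetero atoms), on a carbonyl carbon and this made a 1.9-fold higher number from compound 1 to compound 3 (0.29 log units; within the scatter) in this assay. The difference between the cores of compound 1 and compound 2 is not broken down here. Compound 4 arises from compound 2 by the same change, namely a group of 7 heavy atoms (5 carbon, 2 oxygen; one six-membered aromatic ring with 1 hetero atom) in place of a group of 6 heavy atoms (4 carbon, 2 nitrogen; one five-membered aromatic ring with 2 hetero atoms), on a carbonyl carbon at an identical place. Going by the values given here, the step is expected to be a 1.7-fold higher number from compound 2 to compound 4 (0.23 log units; within the scatter) because of a 1.9-fold higher number from compound 1 to compound 3 (0.29 log units; within the scatter) as the only precedent. Compound 4 is therefore estimated at 75000 nM in this assay, with a range expected from 35000 nM to 160000 nM around it.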

Compound 4, half-maximal inhibitory concentration: 83800 nM
For compound 4 the middle estimate is 1.1-fold (0.05 log units) below the measured one, and the stated range covers the measured number.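

Exchanging the 1-methyl-1H-imidazol-4-yl group on the carbonyl carbon for the entering oxygen-containing six-membered ring gives a 1.9-fold higher number from compound 2 to compound 4 (0.28 log units; within the scatter) in this assay. Set beside the earlier step, the change has the same size on both cores shown: the same change on two cores in this assay, a 1.9-fold higher number (0.29 log units; within the scatter) from compound 1 to compound 3 and a 1.9-fold higher number (0.28 log units; within the scatter) from compound 2 to compound 4, 1.0-fold (0.01 log units) apart, within the scatter of two such steps. Each step on its own lies within the scatter; the agreement therefore does not establish that this exchange weakens inhibition, and two cores support no rule for the wider series.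

As far as these compounds go, it remains open whether a different group on this carbonyl carbon, such as a pyridine ring, a morpholine or a chain ending in a carboxylic acid, would shift the number beyond the scatter. From the compounds shown here alone, whether the two cores would also match for such groups is equally open.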